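Replacing the nitrophenyl ether with a trifluorophenyl ether

The source may report more compounds than this note shows. Statements on the series, on what has been measured and on what is new or still open speak of the compounds shown alone.

Measured compounds:
- compound 1 `CC(C)[C@H](NC(=O)COc1cccc2ccccc12)C(=O)N[C@@H](CC(=O)O)C(=O)COc1ccc(Oc2ccccc2)cc1`: 19000 nM
- compound 2 `CC(C)[C@H](NC(=O)COc1cccc2ccccc12)C(=O)N[C@@H](CC(=O)O)C(=O)COc1ccc(Oc2ccc(C(F)(F)F)cc2)cc1`: 24900 nM
- compound 3 `CC(C)[C@H](NC(=O)COc1cccc2ccccc12)C(=O)N[C@@H](CC(=O)O)C(=O)COc1ccccc1[N+](=O)[O-]`: 27700 nM

These three values come from a functional assay with Homo sapiens as the target; a higher number here means a weaker inhibitor, a lower number a stronger inhibitor. Within the data shown here, the one measured step, a 1.3-fold higher number from compound 1 to compound 2 (0.12 log units; within the scatter), left the number within the scatter. Compound 3 lies within the scatter of both compound 1 and compound 2, so the three compounds cannot be told apart on these numbers.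

Compound 4 `CC(C)[C@H](NC(=O)COc1cccc2ccccc12)C(=O)N[C@@H](CC(=O)O)C(=O)COc1cc(F)cc(F)c1F` differs from compound 3 by 2,3,5-trifluorophenyl in place of 2-nitrophenyl on an oxygen on a saturated carbon. Among the measured compounds shown here, no measured step covers this exchange; the only step in hand, a 1.3-fold higher number from compound 1 to compound 2 (0.12 log units; within the scatter), concerns a different aryl group and stayed within the scatter. With nothing pointing elsewhere, the expected step is a 1.0-fold lower number from compound 3 to compound 4 (0.01 log units; within the scatter), which would keep the number within the scatter. Compound 4 is therefore estimated at 27000 nM, with a range from 9000 nM to 80000 nM.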

Compound 4, half-maximal inhibitory concentration: 11200 nM
Beside the measured number, compound 4's estimate is 2.4-fold (0.38 log units) above it; the measured number falls inside the stated range.
By their numbers in this assay, from the lowest: compounds 4, 1, 2 and 3 (each within the scatter of the next, the first and the last beyond it).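

In this assay, the aryl group on this ether oxygen can move the number beyond the scatter: 2,3,5-trifluorophenyl in place of 2-nitrophenyl gives a 2.5-fold lower number from compound 3 to compound 4 (0.39 log units; beyond the scatter). Among these compounds, compounds 1, 2 and 3 could not be told apart, so this modest step is the first sign that this position responds to a change. Nothing measured here explains the step.

On these data alone, it remains open which of the three fluorines matter, and where a plain phenyl would fall. An amine or a carboxylic acid on this ring is also untested among the compounds shown.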